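From an open chain back to a piperidine amide

The source may report more compounds than this note shows. Statements on the series, on what has been measured and on what is new or still open speak of the compounds shown alone.

Compound 1 `Cc1nc(N2CCC(NS(=O)(=O)N(C)C)CC2)nc2ccc(NC(=O)/C=C/c3ccc(OC(F)(F)F)cc3)cc12`: 105 nM
Compound 2 `Cc1nc(N2CCC(N3CCOC3=O)CC2)nc2ccc(NC(=O)/C=C/c3ccc(OC(F)(F)F)cc3)cc12`: 41 nM
Compound 3 `Cc1nc(NCCNC(=O)C2CC2)nc2ccc(NC(=O)/C=C/c3ccc(OC(F)(F)F)cc3)cc12`: 61 nM
Compound 4 `COCC(=O)NC1CCN(c2nc(C)c3cc(NC(=O)/C=C/c4ccc(OC(F)(F)F)cc4)ccc3n2)CC1`: not yet measured

In an assay on CHO-K1 cells for displacement of a labelled ligand from melanin-concentrating hormone receptor 1 (Homo sapiens), read by scintillation proximity assay, with a stated time of 2 h (a lower number here means a stronger inhibitor, a higher number a weaker inhibitor), compound 3 stands second highest of the three numbers, within the scatter of both compound 2 and compound 1. The change to compound 4 is 4-(((methoxymethyl)carbonyl)amino)piperidin-1-yl in place of (2-((cyclopropylcarbonyl)amino)ethyl)amino on an aromatic carbon. For the measured compounds named here, two measured steps bear on it: a 2.6-fold lower number from compound 1 to compound 2 (0.41 log units; beyond the scatter) swapped the group on the piperidine ring, and a 1.5-fold higher number from compound 2 to compound 3 (0.17 log units; within the scatter) opened the ring into a chain. Compound 4 returns to a piperidine with an amide on its saturated carbon, the arrangement shared by compound 1 and compound 2, so in this assay a step of a 1.1-fold lower number from compound 3 to compound 4 (0.04 log units; within the scatter) is expected, within the scatter. Compound 4 is therefore estimated at 55 nM, with a range of 22 nM to 140 nM.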

Compound 4, half-maximal inhibitory concentration: 32 nM
For compound 4 the middle estimate is 1.7-fold (0.24 log units) above the measured one; the range from low to high includes it.
By their numbers in this assay, from the lowest: compounds 4, 2, 3 and 1 (each within the scatter of the next, the first and the last beyond it).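

In this assay, the amine nitrogen on the piperidine ring responds to its substituent: (methoxymethyl)carbonyl in place of dimethylsulfamoyl gives a step beyond the scatter (a 3.3-fold lower number from compound 1 to compound 4 (0.52 log units; beyond the scatter)). The other two changes stay within the scatter, whether the group is swapped for 2-oxo-1,3-oxazolidin-3-yl (a 1.3-fold lower number from compound 2 to compound 4 (0.11 log units; within the scatter)) or the whole piperidine unit is swapped for the open chain (a 1.9-fold lower number from compound 3 to compound 4 (0.28 log units; within the scatter)). No measurement shown here explains these numbers. Still open, from the compounds shown here alone, is how a free amine, or a carboxylic acid on a longer chain, would behave on that piperidine.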